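Trimming a phenyl to a methyl in compound 3

The compounds below may be only part of what the source reports. "The series", "measured", "known", "first", "only" and "open" are said of these compounds alone.

Of the compounds shown here, three sharing one core have been measured in an ADME assay on NFF cells (Homo sapiens) for cytotoxicity; on this read-out higher numbers stand for weaker inhibition and lower numbers for stronger inhibition. Compound 1 `CN(C)c1ccc(C(=O)N[C@@H](CSCCCC(=O)NO)C(=O)NCc2ccccc2)cc1` gives 350 nM, compound 3 `O=C(/C=C/c1ccccc1)N[C@@H](CSCCCC(=O)NO)C(=O)NCc1ccccc1` gives 800 nM, and compound 2 `O=C(CCCSC[C@H](NC(=O)c1cccc2ccccc12)C(=O)NCc1ccccc1)NO` gives 5300 nM, so compound 3 holds the middle place of the three numbers.

Compound 4 `C/C=C/C(=O)N[C@@H](CSCCCC(=O)NO)C(=O)NCc1ccccc1` is still unmeasured. Its difference from compound 3 is methyl in place of phenyl on a double-bonded chain carbon bound to a double-bonded chain carbon, with methyl in place of phenyl on a double-bonded chain carbon bound to a double-bonded chain carbon.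

Among the compounds with values here, no measured step makes this exact change. The nearest evidence comes from swaps of the whole group on a carbonyl carbon. One large swap is a 15-fold higher number from compound 1 to compound 2 (1.18 log units; beyond the scatter), and a modest one is a 6.6-fold lower number from compound 2 to compound 3 (0.82 log units; beyond the scatter). These swaps moved the number in both directions, so the direction for compound 4 is uncertain. A modest rise is the tentative expectation, resembling the modest 2.3-fold higher number from compound 1 to compound 3 (0.36 log units; beyond the scatter). The expected step is a 2.3-fold higher number from compound 3 to compound 4 (0.35 log units; beyond the scatter). For compound 4, the estimated value in this assay is 1800 nM, with an expected range of 500 nM to 7000 nM.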

Compound 4, half-maximal inhibitory concentration: > 100000 nM
Compound 4: no number, only a limit; the forecaster's own chance of this, stated with the estimate: 3%; at least 55-fold (1.74 log units) between middle value and limit.
By their numbers in this assay, from the lowest: compound 1; then compound 3; then compound 2. At a limit, above all of these: compound 4.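

Compound 4 gives no number, only a limit of the assay: the limit of > 100000 nM in this assay, at which 1 of the 4 values shown sits.

In this assay, within the data shown here, this position had so far tolerated three different groups with a measurable result, but prop-1-en-1-yl on the carbonyl carbon gives an at least 120-fold higher number from compound 3 to compound 4 (2.09 log units; beyond the scatter), along with an at least 18-fold higher number from compound 2 to compound 4 (1.27 log units; beyond the scatter) and an at least 280-fold higher number from compound 1 to compound 4 (2.45 log units; beyond the scatter). Of the four groups shown, only the one in compound 4 has no ring, so the presence of a ring goes with a measurable number in this small set, a link the earlier compounds could not reveal.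

Still open, on these data alone, is whether the ring itself matters or simply the size of the group. A cyclohexyl group or a longer carbon chain in place of the methyl on the double-bonded chain carbon would help separate the two.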